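Hydrazone aryl substituent in the shared core series

The source may hold more compounds than are shown below. What is called first, only, known or untested is meant among the compounds shown, and "the series" means these compounds.

Two members of this series have been measured so far. Compound 1 `Nc1c(C(=O)N/N=C/c2ccccc2)oc2nc(-c3ccccc3)cc(C(F)(F)F)c12` carries a phenyl on the shared core and an unsubstituted benzylidene hydrazide, while compound 2 `Cc1ccc(/C=N/NC(=O)c2oc3nc(-c4cccs4)cc(C(F)(F)F)c3c2N)cc1` carries a thienyl on the core and a 4-methylphenyl on the hydrazone. In a functional assay on HepG2 cells (Homo sapiens) for antiproliferative activity, read by MTT assay (a lower number here means a stronger inhibitor, a higher number a weaker inhibitor), compound 1 gives 13100 nM. In this assay compound 2 gives 19800 nM, the highest of the two numbers, with compound 1 the nearest; the gap between them lies within the scatter, so no order between the two is read from it. Within the data shown here, the two compounds differ in more than one place, so no single-point step is available from them.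

Compound 3 `Nc1c(C(=O)N/N=C/c2ccc(Br)cc2)oc2nc(-c3cccs3)cc(C(F)(F)F)c12` is not yet measured in this assay. Against compound 2 the difference is bromo in place of methyl on an aromatic carbon, a change of one heavy atom on the 4-methylphenyl to 4-bromophenyl ring. With no measured step of this kind in the series, the expected step of a 1.3-fold lower number from compound 2 to compound 3 (0.12 log units; within the scatter) is not beyond the scatter, with at most a slight drift toward a lower number. Compound 3 is therefore estimated at 15000 nM, expected to fall between 5000 nM and 45000 nM.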

Compound 3, half-maximal inhibitory concentration: 6100 nM
Estimate against measurement, compound 3: 2.5-fold (0.39 log units) above, and the stated range covers the measured number.
By their numbers in this assay, from the lowest: compound 3; then compounds 1 and 2 (each within the scatter of the next).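

Bromo in place of methyl on an aromatic carbon, para to a large group, gives the first single-point step in this series: in this assay the change gives a 3.2-fold lower number from compound 2 to compound 3 (0.51 log units; beyond the scatter), with the thienyl on the shared core unchanged. This shows that a one-atom exchange at this position of the hydrazone aryl ring can move the number beyond the scatter, something the earlier pair could not show, as those two compounds differ in more than one place. Nothing at hand bears on what lies behind this step.

The compounds shown leave open whether the same exchange would give a similar step with the phenyl on the core of compound 1, and whether the lower number is particular to bromo or would also appear with chloro, methoxy or an amine at the same place. Among these compounds, with only one step at this position, the result remains a single observation rather than a trend, and the unsubstituted benzylidene of compound 1 offers no matching comparison on the thienyl core.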